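This account rests on a few compounds, and the source may have more. Where it says the series, first, only, none or still open, it means among the compounds named here.

Compound 1 `CC(C)C(CC(N)=O)c1ccc(-c2ccc3cccc(F)c3c2)[nH]c1=O`; compound 2 `CC(C)C(c1cnc(N)s1)c1ccc(-c2ccc3cccc(F)c3c2)[nH]c1=O`; compound 3 `CC(C)C(Nc1nnc[nH]1)c1ccc(-c2ccc3cccc(F)c3c2)[nH]c1=O`.

In an ADME assay on microsomes from liver (Rattus norvegicus) for metabolic stability (on this read-out higher numbers stand for a longer-lived compound and lower numbers for a shorter-lived compound), compound 1 gives only a limit, < 0.0667 h, which is the limit of < 0.0667 h in this assay, at which 1 of the 3 values shown sits. In this assay compound 2 gives 0.0983 h and compound 3 gives 1.29 h. Compound 3 stands highest of the numbers shown; the steps up to it were an at least 19-fold higher number from compound 1 to compound 3 (1.28 log units; beyond the scatter) and a 13-fold higher number from compound 2 to compound 3 (1.12 log units; beyond the scatter), both large.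

Compound 4 `CC(C)C(Cc1noc(=O)[nH]1)c1ccc(-c2ccc3cccc(F)c3c2)[nH]c1=O` differs from compound 3 in one place: a group of 7 heavy atoms (3 carbon, 2 nitrogen, 2 oxygen; one five-membered aromatic ring with 3 hetero atoms) in place of a group of 6 heavy atoms (2 carbon, 4 nitrogen; one five-membered aromatic ring with 3 hetero atoms), on a saturated chain carbon bound to an aromatic carbon and a saturated chain carbon. Both measured steps bear on this change, since each put the group that now leaves in place of something else and each was a large gain. For compound 4 a large step downward in this assay is therefore expected, a 5.2-fold lower number from compound 3 to compound 4 (0.71 log units; beyond the scatter). Compound 4 is estimated at 0.25 h, with a range from 0.07 h to 1 h.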

Compound 4, half-life: > 3 h
Compound 4 ended at the assay's limit; the forecaster's own chance of this, stated with the estimate: 20%; middle value at least 12-fold (1.07 log units) away from the limit.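

A long half-life at this position does not need the (4H-1,2,4-triazol-3-yl)amino group: in this assay, the group of 7 heavy atoms gives an at least 2.3-fold higher number from compound 3 to compound 4 (0.36 log units; beyond the scatter). Against the two shorter-lived compounds the steps are large, with an at least 30-fold higher number from compound 2 to compound 4 (1.48 log units; beyond the scatter) and an at least 44-fold higher number from compound 1 to compound 4 (1.65 log units; beyond the scatter). Compound 4 gives only a limit: the limit of > 3 h in this assay, at which 1 of the 4 values shown sits.

Going by these compounds, how far compound 4 truly lies above compound 3 stays open. So does what these groups do to the half-life, and whether a carboxylic acid on the same saturated chain carbon would last as long.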